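Ethoxy to propoxy on compound 1

This account rests on a few compounds, and the source may have more. Where it says the series, first, only, none or still open, it means among the compounds named here.

Compound 1 `CCOc1ccc(/C=C/c2cc(OC)c(OC)c(OC)c2)cc1`: 1.7 uM
Compound 2 `COC(=O)C(Cc1cc(OC)c(OC)c(OC)c1)c1ccc(OC)cc1`: > 25 uM
Compound 3 `CCOc1ccc(/C=C\c2cc(OC)c(OC)c(OC)c2)cc1`: 1.6 uM

In a functional assay on A549 cells (Homo sapiens) for cytotoxicity (on this read-out lower numbers stand for an effect already at smaller amounts and higher numbers for an effect only at larger amounts of compound), compound 1 gives 1.7 uM and has one close neighbour among the numbers: a 1.1-fold lower number from compound 1 to compound 3 (0.03 log units; within the scatter). For compound 2 the entry > 25 uM is a limit, not a number.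

Compound 4 `CCCOc1ccc(/C=C/c2cc(OC)c(OC)c(OC)c2)cc1` departs from compound 1 by one change, ethoxy to propoxy: methyl in place of hydrogen on a saturated chain carbon, two bonds along the chain from an oxygen on an aromatic ring. The only measured step, the one given above, bears on (the fact that compounds 1 and 3 differ only in the configuration as drawn), so no measurement in the series covers a change of chain length. No step beyond the scatter is therefore expected in this assay, and the expected step is a 1.3-fold higher number from compound 1 to compound 4 (0.11 log units; within the scatter). For compound 4 the estimated value is 2.2 uM, with an expected range of 0.8 uM to 7 uM.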

Compound 4, concentration for half-maximal effect: 9.2 uM
Compound 4: middle estimate off by 4.2-fold (0.62 log units), on the low side; the whole stated range lies below it.
By their numbers in this assay, from the lowest: compounds 3 and 1 (each within the scatter of the next); then compound 4. At a limit, above all of these: compound 2.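

In this assay, a 5.4-fold higher number from compound 1 to compound 4 (0.73 log units; beyond the scatter) is a step beyond the scatter, so this saturated chain carbon does not tolerate every extension of the ethoxy group without a change in the number. For the compounds shown here, the earlier compounds gave no reading on chain length, as their only measured step concerned the double-bond configuration. Nothing shown here accounts for the size of this step.

Open: whether a butoxy group would extend the trend, and whether a branched isopropoxy group would read like propoxy. Also open, from the compounds shown here alone, is whether the same change on compound 3 gives a similar step.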